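The compounds below may be only part of what the source reports. "The series", "measured", "known", "first", "only" and "open" are said of these compounds alone.

Measured compounds:
Compound 1 `OC[C@H]1OC(n2cnc3c(-c4cc[nH]c4)ncnc32)[C@H](O)[C@@H]1O`: in a functional assay on CCRF-CEM cells (Homo sapiens) for inhibition (on this read-out higher numbers stand for weaker inhibition and lower numbers for stronger inhibition), compound 1 gives 1030 nM.
Compound 2 `Cc1ccsc1-c1ncnc2c1ncn2C1O[C@H](CO)[C@@H](O)[C@H]1O`: in this assay compound 2 gives 2500 nM.
Compound 3 `OC[C@H]1OC(n2cnc3c(-c4nccs4)ncnc32)[C@H](O)[C@@H]1O`: in this assay compound 3 gives 2730 nM.

Compound 3 shows the highest of the three numbers, but the step of a 1.1-fold higher number from compound 2 to compound 3 (0.04 log units; within the scatter) lies within the scatter, so no order between these two can be claimed, whereas the step of a 2.7-fold higher number from compound 1 to compound 3 (0.42 log units; beyond the scatter) lies beyond it. Compound 4 `OC[C@H]1OC(n2cnc3c(-c4cc[nH]n4)ncnc32)[C@H](O)[C@@H]1O` differs from compound 3 in one place: 1H-pyrazol-3-yl in place of 1,3-thiazol-2-yl on an aromatic carbon. Going by the values given here, two measured steps bear on this change. Replacing the 1H-pyrrol-3-yl group of compound 1 by either five-membered ring without a hydrogen-bond donor raised the number in both cases: a 2.4-fold higher number from compound 1 to compound 2 (0.39 log units; beyond the scatter) and a 2.7-fold higher number from compound 1 to compound 3 (0.42 log units; beyond the scatter). Swapping the two donor-free rings for one another made no difference beyond the scatter. The entering 1H-pyrazol-3-yl group brings one hydrogen-bond donor, as the count shows, which the leaving 1,3-thiazol-2-yl lacked. Compound 4 is therefore expected to return a somewhat lower number, a 1.8-fold lower number from compound 3 to compound 4 (0.26 log units; within the scatter), though three compounds are too few to be sure. The estimate for compound 4 in this assay is 1500 nM, with a range from 600 nM to 4000 nM.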

Compound 4, half-maximal inhibitory concentration: 750 nM
Estimate against measurement, compound 4: 2.0-fold (0.30 log units) above, and the stated range covers the measured number.
By their numbers in this assay, from the lowest: compounds 4 and 1 (each within the scatter of the next); then compounds 2 and 3 (each within the scatter of the next).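

The 1H-pyrazol-3-yl group has the same heavy-atom count as 1,3-thiazol-2-yl and also has two ring hetero atoms, yet a 3.6-fold lower number from compound 3 to compound 4 (0.56 log units; beyond the scatter) is beyond the scatter, as is a 3.3-fold lower number from compound 2 to compound 4 (0.52 log units; beyond the scatter) in the comparison with the 3-methylthiophen-2-yl ring. Both rings with a ring hydrogen on nitrogen now give lower numbers than both rings without one, with no exception among these four compounds, while a 1.4-fold lower number from compound 1 to compound 4 (0.14 log units; within the scatter) is within the scatter, so pyrazole and pyrrole cannot be told apart here. Nothing available explains this pattern. On these data alone, whether that ring hydrogen is what matters remains open, since a phenyl ring, a pyridine ring or an open-chain amine at this carbon would test the pattern beyond five-membered aromatic rings. The same holds for a carboxylic acid.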